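A few compounds are considered here, and "the series" means these few. Any claim that something is new, unique, unknown or untested is made for them only; others in the source may bear on it.

Compound 1 `CCNC(=O)c1cc2c(-c3cc(OCCCCCCn4cc(-c5nc(Nc6ccc(NC(=O)CCCCCCC(=O)NO)cc6)nc6[nH]ccc56)cn4)c(Cl)cc3Cl)nc(N)nc2s1` gives 2820 nM in an assay on isolated protein for inhibition of protein deacetylase HDAC6 (Homo sapiens), read by fluorescence, with a stated time of 2 h; a higher number here means a weaker inhibitor, a lower number a stronger inhibitor.
Compound 2 `CCNC(=O)c1cc2c(-c3cccc(OCCCCCCOc4ccc(Nc5nc(-c6cnn(CCCCCCC(=O)NO)c6)c6cc[nH]c6n5)cc4)c3)nc(N)nc2s1` gives 8 nM in this assay.

Compound 1 stands as the higher of the two numbers, the weaker inhibitor. The gap between compound 1 and compound 2 lies well beyond the scatter. Compound 3 `CCNC(=O)c1cc2c(-c3cc(OCCCCCCn4cc(-c5nc(Nc6ccc(NC(=O)CCCCCCC(=O)O)cc6)nc6[nH]ccc56)cn4)c(Cl)cc3Cl)nc(N)nc2s1` differs from compound 1 by hydroxy in place of hydroxyamino on a carbonyl carbon. Among the compounds with values here, no measured step of this kind is available here, so the expectation rests only on compound 1 and its value 2820 nM. An upward step is expected, an 11-fold higher number from compound 1 to compound 3 (1.03 log units; beyond the scatter), beyond the scatter. Compound 3 is estimated at 30000 nM, within 8000 nM to 150000 nM.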

Compound 3, half-maximal inhibitory concentration: 6300 nM
Estimate against measurement, compound 3: 4.8-fold (0.68 log units) above; the whole stated range lies above it.
By their numbers in this assay, from the lowest: compound 2; then compound 1; then compound 3.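

In this assay, hydroxy in place of hydroxyamino on a carbonyl carbon gives a 2.2-fold higher number from compound 1 to compound 3 (0.35 log units; beyond the scatter) and so only a modest loss, which shows that on the already weak compound 1 the hydroxycarbamoyl group at this position carries little of the remaining inhibition. No measurement shown here accounts for the size of this step. As far as these compounds go, whether the same change would cost more on the far stronger compound 2 stays open. Also open, from the compounds shown here alone, is what a primary amide or a methyl ester would give at this position on compound 1.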